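A few compounds are considered here, and "the series" means these few. Any claim that something is new, unique, unknown or untested is made for them only; others in the source may bear on it.

Measured compounds:
compound 1 `O=C(Nc1cccc(-n2cc(-c3ccncc3)c(-c3cc(O)cc(Cl)c3)n2)c1)Nc1ccc(Cl)c(Cl)c1` gives -69.2%
compound 2 `COc1cc(Cl)cc(-c2nn(-c3cccc(NC(=O)Nc4ccc(Cl)c(Cl)c4)c3)cc2-c2ccncc2)c1` gives 18.7%
compound 3 `O=C(Nc1cccc(-n2cc(-c3ccncc3)c(-c3cc(O)cc(Cl)c3)n2)c1)c1cc(C(F)(F)F)cc(C(F)(F)F)c1` gives 24.5%

In a functional assay on M14 cells (Homo sapiens) for inhibition, read by sulforhodamine B assay, with a stated time of 48 h, tested at 10 uM (on this read-out lower numbers stand for a stronger effect and higher numbers for a weaker effect at the one concentration tested), compound 1 gives -69.2%. Compound 2 differs from compound 1 in one place, (methyl in place of hydrogen on an oxygen on an aromatic ring), and that single change moved the read-out by a number 87.9 percentage points higher from compound 1 to compound 2 (beyond the scatter). Compound 3 carries a different core; the difference between the cores of compound 1 and compound 3 is not broken down here. In this assay compound 3 gives 24.5%, which sits within the usual scatter of the value of compound 2.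

Compound 4 `COc1cc(Cl)cc(-c2nn(-c3cccc(NC(=O)c4cc(C(F)(F)F)cc(C(F)(F)F)c4)c3)cc2-c2ccncc2)c1` has not been measured yet. It differs from compound 3 by methyl in place of hydrogen on an oxygen on an aromatic ring, the same change that separates compound 1 from compound 2; among these compounds it occurs twice. For compound 4 a step of a number 30.5 percentage points higher from compound 3 to compound 4 (beyond the scatter) in this assay is expected, in the same direction as the earlier step but smaller, because compound 3 already stands at 24.5% rather than far below zero. Compound 4 is therefore estimated to give 55%, with a range from 15% to 95%.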

Compound 4, a percentage reported as activity, at one concentration (the size of the read-out at that concentration, not a potency): 67.3%
Beside the measured number, compound 4's estimate is 12.3 percentage points below it; the range from low to high includes it.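

In this assay, the change from hydroxy to methoxy on the 3-chloro-5-hydroxyphenyl group gives a number 42.8 percentage points higher from compound 3 to compound 4 (beyond the scatter). On this read-out a higher number means a weaker effect, so the change weakens the effect on both cores, and its direction carries over while its size does not: the same change on two cores in this assay, a number 87.9 percentage points higher (beyond the scatter) from compound 1 to compound 2 and a number 42.8 percentage points higher (beyond the scatter) from compound 3 to compound 4, 45.1 percentage points apart, beyond the scatter of two such steps. Two cores are too few to predict the size of the step on a third, and these numbers do not explain why the two sizes differ.

The compounds shown leave open whether the loss comes from removing the hydrogen on the oxygen or from adding the methyl, since an amine in place of the hydroxy or a longer chain such as ethyl on the oxygen does not appear among them. It also remains open how the two steps would compare at other concentrations or in other cell types, as only one concentration and one cell line are shown here.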